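A Second Hydroxyl on the Amide Side Chain of Compound 1

This account rests on a few compounds, and the source may have more. Where it says the series, first, only, none or still open, it means among the compounds named here.

Compound 1, `CCn1c(C(=O)NCC(=O)OC)ccc1C(CC)(CC)c1ccc(OCS(=O)(=O)c2ccccc2)c(C)c1`, gives > 50000 nM in a functional assay on MCF7 cells (Homo sapiens) for antiproliferative activity, read by MTT assay, with a stated time of 24 h (on this read-out higher numbers stand for weaker inhibition and lower numbers for stronger inhibition), which is a limit of the assay rather than a number.
Compound 2, `CCn1c(C(=O)N[C@H](C)C(=O)OC)ccc1C(CC)(CC)c1ccc(OCS(=O)(=O)c2ccccc2)c(C)c1`, gives > 50000 nM in this assay, also a limit.
Compound 3, `CCn1c(C(=O)N[C@@H](CO)C(C)C)ccc1C(CC)(CC)c1ccc(OCS(=O)(=O)c2ccccc2)c(C)c1`, gives 18800 nM in this assay.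

Compound 1 therefore stands only at a limit on the numbers shown, and among the three values (the limit of > 50000 nM in this assay, at which 2 of the 3 values shown sit). The step to compound 2, a step that the two limits leave unreadable from compound 1 to compound 2, cannot be read. Compound 4, `CCn1c(C(=O)N[C@@H](CO)CCO)ccc1C(CC)(CC)c1ccc(OCS(=O)(=O)c2ccccc2)c(C)c1`, differs from compound 1 by 3-hydroxy-1-(hydroxymethyl)propyl in place of (methoxycarbonyl)methyl on an amide-type nitrogen.

Two measured steps speak to this change. In an at least 2.6-fold lower number from compound 1 to compound 3 (0.42 log units; beyond the scatter) and in an at least 2.6-fold lower number from compound 2 to compound 3 (0.42 log units; beyond the scatter), an ester-bearing chain on the amide-type nitrogen was exchanged for a chain carrying a hydroxymethyl, and each time a readable number appeared in place of a limit. The chain entering compound 4 also carries a hydroxymethyl, together with a second hydroxyl in place of the branched methyl groups of compound 3, so a step of at least modest size in the same direction, towards a lower number, is expected, though a limit may still be reported.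

Compound 4 is therefore estimated at 25000 nM, within 9000 nM to 60000 nM, corresponding to the expected step of an at least 2.0-fold lower number from compound 1 to compound 4 (0.30 log units; that floor lies within the scatter).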

Compound 4, half-maximal inhibitory concentration: 27400 nM
Estimate against measurement, compound 4: 1.1-fold (0.04 log units) below; the measured number falls inside the stated range.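

With compound 4, a second amide side chain that lacks the methyl ester and carries a hydroxymethyl also gives a readable number in this assay, so this outcome no longer rests on compound 3 alone: an at least 1.8-fold lower number from compound 1 to compound 4 (0.26 log units; that floor lies within the scatter), and an at least 1.8-fold lower number from compound 2 to compound 4 (0.26 log units; that floor lies within the scatter). These floors give no true size for either step, since compound 1 and compound 2 each stand only at a limit of the assay, not at a number: the limit of > 50000 nM in this assay, at which 2 of the 4 values shown sit. Placing 2-hydroxyethyl where compound 3 has isopropyl, on the saturated chain carbon bound to the amide-type nitrogen, gives a 1.5-fold higher number from compound 3 to compound 4 (0.16 log units; within the scatter), so on this read-out the two chains cannot be told apart and a readable number does not depend on the isopropyl group.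

The compounds shown leave open whether the hydroxyl groups matter in themselves or whether losing the methyl ester is enough, a question that a plain alkyl chain with no hydroxyl on the amide-type nitrogen could help to settle. Going by these compounds, it also remains open how an amine, a carboxylic acid or a longer chain in place of the 2-hydroxyethyl group would read in this assay.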